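Stepping from Compound 3 to Compound 4

The source may hold more compounds than are shown below. What is called first, only, known or untested is meant among the compounds shown, and "the series" means these compounds.

Of the compounds shown here, three of one shared core have so far been measured in an ADME assay on the whole organism with Oryza sativa as the target, tested at 1 uM; on this read-out higher numbers stand for a weaker effect at the one concentration tested and lower numbers for a stronger effect. Compound 1 `Cc1ccccc1NC(=O)N[C@H](C)c1ccccc1` gives 100%. Compound 2 `CCc1ccccc1NC(=O)N[C@H](C)c1ccccc1` gives 100%. Compound 3 `CCc1ccccc1NC(=O)N[C@@H](C)c1ccccc1` gives 100%. Among the measured compounds shown here, compound 3 therefore stands level with both of its neighbours, and no compound among the three can be called stronger or weaker than another.

Two steps connect these measured compounds. Methyl in place of hydrogen on a saturated chain carbon bound to an aromatic carbon gives no change at the digits printed from compound 1 to compound 2 (within the scatter). The next step, in which the two compounds have the same atoms and bonds and differ only in configuration as drawn (the fact that compounds 2 and 3 differ only in the configuration as drawn), gives no change at the digits printed from compound 2 to compound 3 (within the scatter).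

Compound 4 `C[C@H](NC(=O)Nc1ccccc1C(C)(C)C)c1ccccc1` has not yet been measured. It differs from compound 3 in one place: tert-butyl in place of ethyl on an aromatic carbon. The closest measured step, the one that also enlarges a group on or next to the aromatic ring of carbon only, is the step from compound 1 to compound 2, and it showed no change beyond the scatter. The expected step of no change at the digits printed from compound 3 to compound 4 (within the scatter) is therefore none beyond the scatter. Compound 4 is estimated to give 100%, with a range from 90% to 100%.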

Compound 4, a percentage reported as activity, at one concentration (the size of the read-out at that concentration, not a potency): 99%
Beside the measured number, compound 4's estimate is 1 percentage points above it; low and high end bracket the measured number.
By their numbers in this assay, from the lowest: compounds 4, 1, 2 and 3 (each within the scatter of the next).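

In this assay, tert-butyl in place of ethyl, on an aromatic carbon of a six-membered aromatic ring of carbon only and ortho to a large group, gives a number 1 percentage points lower from compound 3 to compound 4 (within the scatter), so this position accepts a clearly larger group without any shift beyond the scatter. Among the compounds shown here, until now this substituent had been seen only as methyl and ethyl; the new result widens the range to a group of 4 heavy atoms, all carbon, in place of one of 2, and the read-out still shows no separation among the compounds. Nothing among the facts at hand bears on why enlarging this group leaves the read-out within the scatter.

From the compounds shown here alone, all the groups tried at this position are purely carbon chains or branches, so it remains open whether a group with other atoms, such as an amine, a methoxy group or a carboxylic acid, would move the read-out here. Going by these compounds, it is also open whether any change elsewhere on the shared core, such as on the urea nitrogens or the second aromatic ring, would separate these compounds.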